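Shortening the alkyl chain: compound 1 to compound 3

This account rests on a few compounds, and the source may have more. Where it says the series, first, only, none or still open, it means among the compounds named here.

Measured in a functional assay on COLO 205 cells (Homo sapiens) for cytotoxicity, read by MTT assay, with a stated time of 24 h; a higher number here means a weaker inhibitor, a lower number a stronger inhibitor:
compound 1 `CCCCCc1cc2ccccc2nc1-c1cn(CCC(F)(F)C(F)(F)C(F)(F)C(F)(F)C(F)(F)C(F)(F)C(F)(F)C(F)(F)F)nn1` — > 100 ug/mL
compound 2 `CCCCc1cc2ccccc2nc1-c1cn(-c2ccc(F)cc2)nn1` — > 100 ug/mL

Both entries are limits of the assay, not numbers. Compound 1 stands at > 100 ug/mL, a limit and no measured value. Compound 2 likewise reaches only the limit > 100 ug/mL. Hence compound 1 cannot be ranked against compound 2; the two values show only that neither gave a number, and the limit of > 100 ug/mL in this assay, at which 2 of the 2 values shown sit, is all the series offers.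

Compound 3 `CCCCc1cc2ccccc2nc1-c1cn(CCC(F)(F)C(F)(F)C(F)(F)C(F)(F)C(F)(F)C(F)(F)C(F)(F)C(F)(F)F)nn1` differs from compound 1 in one place: hydrogen in place of methyl on a saturated chain carbon, four bonds along the chain from an aromatic carbon. Within the data shown here, compound 2 also carries the butyl chain, but it differs from compound 3 elsewhere as well, so no measured step covers this change. The expected step that the limit leaves unreadable from compound 1 to compound 3 is none beyond the scatter. Compound 3 is expected to stay at the limit, estimated at 150 ug/mL with a range of 50 ug/mL to 500 ug/mL.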

Compound 3, half-maximal inhibitory concentration: > 100 ug/mL
Compound 3: only a limit was reported (the forecaster's own chance of this, stated with the estimate: 85%); the middle value lies beyond the limit too.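

Compound 3 gives > 100 ug/mL, which is a limit and not a number. Among these compounds, compound 1 also stands at a limit, so no step from compound 1 to compound 3 can be read. The compounds shown leave open whether hydrogen in place of methyl changes cytotoxicity at all, because the series offers only this: the limit of > 100 ug/mL in this assay, at which 3 of the 3 values shown sit.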